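Moving the Pyridine Nitrogen: From Compound 2 to Compound 3

The source may report more compounds than this note shows. Statements on the series, on what has been measured and on what is new or still open speak of the compounds shown alone.

Compound 1, `COc1ccccc1-n1nc(C2CC(C)(C)OC(C)(C)C2)cc1-c1ccc(Cl)cc1`, gives 16 nM in an assay on HEK293 cells for inhibition of Voltage-dependent N-type calcium channel subunit alpha-1B (Homo sapiens), read by patch clamp, using a membrane potential dye; a lower number here means a stronger inhibitor, a higher number a weaker inhibitor.
Compound 2, `CC1(C)CC(c2cc(-c3ccc(Cl)cc3)n(-c3ccncc3)n2)CC(C)(C)O1`, gives 22000 nM in this assay.

Among the measured compounds shown here, compound 2 stands at the highest of the two measured numbers; the only other compound, compound 1, sits far lower, and the one measured step, a 1400-fold higher number from compound 1 to compound 2 (3.14 log units; beyond the scatter), shows how strongly the group on the aromatic nitrogen governs this assay. Compound 3, `CC1(C)CC(c2cc(-c3ccc(Cl)cc3)n(-c3ccccn3)n2)CC(C)(C)O1`, keeps everything of compound 2 and differs in one place: pyridin-2-yl in place of pyridin-4-yl on an aromatic nitrogen. For the measured compounds named here, no measured step covers a pyridine with its nitrogen shifted, so the direction cannot be read directly from the data; the large step from compound 1 to compound 2 only says that this position matters. A moderate move back toward compound 1 is therefore expected, but not a return to its number. Compound 3 is estimated at 8000 nM, with a range from 1500 nM to 40000 nM, meaning an expected step of a 2.8-fold lower number from compound 2 to compound 3 (0.44 log units; beyond the scatter).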

Compound 3, half-maximal inhibitory concentration: 1000 nM
The estimate for compound 3 lay 8.0-fold (0.90 log units) above the measured number, and the stated range ends above it.
By their numbers in this assay, from the lowest: compound 1; then compound 3; then compound 2.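

Compound 2 and compound 3 carry the same atoms and the same counts of donors and acceptors, yet in this assay the step is a 22-fold lower number from compound 2 to compound 3 (1.34 log units; beyond the scatter). So at this position, it matters where the nitrogen sits within the pyridine ring, not only that the ring holds one. Even so, pyridin-2-yl does not fully replace 2-methoxyphenyl, as the step of a 63-fold higher number from compound 1 to compound 3 (1.80 log units; beyond the scatter) shows, and nothing available explains either difference.

Still open, going by these compounds, is where pyridin-3-yl, the remaining way of attaching a pyridine ring, would fall relative to compound 2 and compound 3. Also open, on these data alone, is whether a plain phenyl group, with no methoxy and no ring nitrogen, would come closer to compound 1 than compound 3 does.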